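A few compounds are considered here, and "the series" means these few. Any claim that something is new, unique, unknown or untested is made for them only; others in the source may bear on it.

Compound 1 `CC(C)C(c1ccc(Cl)cc1)S(=O)(=O)Nc1nccs1` is a sulfonamide on an aminothiazole; in a functional assay on CHO cells for agonist activity at Free fatty acid receptor 2 (Homo sapiens), read by cAMP accumulation (on this read-out higher numbers stand for weaker inhibition and lower numbers for stronger inhibition), compound 1 gives > 100000 nM, which is a limit of the assay and not a number (the limit of > 100000 nM in this assay, at which 1 of the 3 values shown sits).
Compound 2 `CC(C)[C@H](C(=O)Nc1ccccn1)c1ccc(Cl)cc1`; in this assay compound 2 gives 1400 nM.
Compound 3 `CC(C)C(C(=O)Nc1cnccn1)c1ccc(Cl)cc1`; in this assay compound 3 gives 5700 nM.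

Among the two numbers shown, compound 2 stands lowest, with compound 3 the nearest and clearly higher, a gap that lies beyond the scatter. Compound 1 reports only a limit.

Compound 4 `CC(C)[C@H](C(=O)Nc1ccon1)c1ccc(Cl)cc1` is not yet measured. It differs from compound 2 in one place: 1,2-oxazol-3-yl in place of pyridin-2-yl on an amide-type nitrogen. Going by the values given here, no two measured compounds differ by this same change, so the size and direction of the step can only be expected, not read off. Compound 4 is expected to sit somewhat weaker than compound 2, a step from compound 2 to compound 4 of about a 2.1-fold higher number from compound 2 to compound 4 (0.33 log units; beyond the scatter), though a value within the scatter of compound 2 would not surprise. For compound 4 the estimate is 3000 nM, with a plausible range from 700 nM to 15000 nM.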

Compound 4, half-maximal inhibitory concentration: 36000 nM
Compound 4: middle estimate off by 12-fold (1.08 log units), on the low side; the measured number lies above the stated range.
By their numbers in this assay, from the lowest: compound 2; then compound 3; then compound 4. At a limit, above all of these: compound 1.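

In this assay, the group on the amide-type nitrogen proves far from interchangeable: 1,2-oxazol-3-yl in place of pyridin-2-yl gives a 26-fold higher number from compound 2 to compound 4 (1.41 log units; beyond the scatter). Going by these compounds alone, this is the first step at this position that can be read as a number, and it is large. A five-membered aromatic ring with 2 hetero atoms therefore does not stand in here for a six-membered aromatic ring with 1 hetero atom, though nothing given here accounts for the size of the step.

The compounds shown leave open whether a plain phenyl group on the amide-type nitrogen, or a methyl group added to the 1,2-oxazol-3-yl, would stay close to compound 2 or fall with compound 4. They also leave open whether this exchange would carry a step of the same size on another core.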